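Fluoro to chloro on the triazole aryl of compound 2

A few compounds are considered here, and "the series" means these few. Any claim that something is new, unique, unknown or untested is made for them only; others in the source may bear on it.

In a functional assay on A549 cells (Homo sapiens) for cytotoxicity, read by MTT assay, with a stated time of 4 days (on this read-out higher numbers stand for weaker inhibition and lower numbers for stronger inhibition), compound 2 `C=C1C(=O)[C@]23C[C@@]1(O)CC[C@H]2c1ccc(O)c(C)c1[C@@H]3Cn1cc(-c2ccc(F)cc2)nn1` gives 940 nM. Among the measured compounds shown here, the only other number measured comes from compound 1 `C=C1C(=O)[C@]23C[C@@]1(O)CC[C@H]2c1ccc(OS(=O)(=O)c2ccc(C)cc2)c(C)c1[C@@H]3Cn1cc(-c2ccc(Cl)cc2)nn1`, which gives 1870 nM in this assay ; the two values lie within the usual scatter of each other, and the pair differs in two places, so no single step is read from it. Compound 3 `C=C1C(=O)[C@]23C[C@@]1(O)CC[C@H]2c1ccc(O)c(C)c1[C@@H]3Cn1cc(-c2ccc(Cl)cc2)nn1` differs from compound 2 by chloro in place of fluoro on an aromatic carbon. For the measured compounds named here, no measured step guides this change, so no shift beyond the scatter is expected, giving an estimated step of a 1.0-fold higher number from compound 2 to compound 3 (0.00 log units; within the scatter). Compound 3 is estimated at 950 nM, expected between 400 nM and 2300 nM.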

Compound 3, half-maximal inhibitory concentration: 640 nM
Compound 3: middle estimate off by 1.5-fold (0.17 log units), on the high side; the range from low to high includes it.
By their numbers in this assay, from the lowest: compounds 3, 2 and 1 (each within the scatter of the next, the first and the last beyond it).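

In this assay, 4-fluorophenyl to 4-chlorophenyl gives a 1.5-fold lower number from compound 2 to compound 3 (0.17 log units; within the scatter), so fluoro and chloro are not told apart at this position. Hydrogen in place of (4-methylphenyl)sulfonyl on the oxygen gives a 2.9-fold lower number from compound 1 to compound 3 (0.47 log units; beyond the scatter), the first single-place step in the series beyond the scatter, though a modest one. Nothing available here explains either step. Open, as far as these compounds go, is how an amine or a methoxy group in place of the halogen would read. Also open, from the compounds shown here alone, is whether a methanesulfonyl or an acetyl group on that oxygen would track the (4-methylphenyl)sulfonyl result.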